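The source may hold more compounds than are shown below. What is called first, only, known or untested is meant among the compounds shown, and "the series" means these compounds.

Working notes on the series. Compound 1 `Cc1cc(O)c(C(C)C)cc1-c1cc(-c2ccccc2[N+](=O)[O-])c(C#N)c(=O)[nH]1` gives in a functional assay for inhibition, tested at 80 ug/mL (a lower number here means a weaker effect, a higher number a stronger effect of the compound at the concentration tested), a read-out of 35%. Compound 2 `Cc1cc(O)c(C(C)C)cc1-c1cc(-c2ccccc2Cl)c(C#N)c(=O)[nH]1` gives 32% in this assay, and the step of a number 3 percentage points lower from compound 1 to compound 2 (within the scatter). Compound 3 `COc1ccc(-c2cc(-c3cc(C(C)C)c(O)cc3C)[nH]c(=O)c2C#N)c(OC)c1` gives 55% in this assay, the highest of the three numbers; the steps of a number 20 percentage points higher from compound 1 to compound 3 (beyond the scatter) and a number 23 percentage points higher from compound 2 to compound 3 (beyond the scatter) both lie beyond the scatter and set compound 3 apart from compound 1 and compound 2.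

Compound 4 `Cc1cc(O)c(C(C)C)cc1-c1cc(-c2cccs2)c(C#N)c(=O)[nH]1` has not yet been measured in this assay. It differs from compound 3 as follows: thiophen-2-yl in place of 2,4-dimethoxyphenyl on an aromatic carbon. The measured steps that bear on this are the two replacements of the group at the same aromatic carbon, a number 20 percentage points higher from compound 1 to compound 3 (beyond the scatter) and a number 23 percentage points higher from compound 2 to compound 3 (beyond the scatter); both were modest and both went upward on arrival at 2,4-dimethoxyphenyl. The present change takes that group away again, so a modest step downward in this assay, back toward the numbers of compound 1 and compound 2, is expected. For the measured compounds named here, no measured compound carries thiophen-2-yl at this position, so the range is kept wide. For compound 4 in this assay the estimated value is 38%, between 22% and 55%. The expected step is a number 17 percentage points lower from compound 3 to compound 4 (beyond the scatter).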

Compound 4, a percentage reported as inhibition, at one concentration (the size of the read-out at that concentration, not a potency): 63%
Estimate against measurement, compound 4: 25 percentage points below, outside the stated range (above it).
By their numbers in this assay, from the lowest: compounds 2 and 1 (each within the scatter of the next); then compounds 3 and 4 (each within the scatter of the next).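

In this assay, the replacement of 2,4-dimethoxyphenyl by thiophen-2-yl gives a number 8 percentage points higher from compound 3 to compound 4 (within the scatter), so the larger read-out at this position does not depend on 2,4-dimethoxyphenyl or its oxygen atoms: a five-membered aromatic ring with 1 hetero atom serves as well as a six-membered aromatic ring of carbon only. Thiophen-2-yl also stands clearly apart from the other two groups, with a number 31 percentage points higher from compound 2 to compound 4 (beyond the scatter) for its replacement of 2-chlorophenyl and a number 28 percentage points higher from compound 1 to compound 4 (beyond the scatter) for its replacement of 2-nitrophenyl, so the four compounds fall into two levels, with 2-chlorophenyl and 2-nitrophenyl at the lower one and the two other groups at the upper one. No measurement at hand accounts for this division into two levels.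

From the compounds shown here alone, it remains open whether the upper level needs an aromatic ring at this carbon at all, as a saturated ring such as cyclohexyl or an amine such as morpholin-4-yl would show. Each read-out also comes from one concentration, so the potency of the compounds at the upper level remains unresolved.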